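Series notes: removal of the dimethylamino group

The source may report more compounds than this note shows. Statements on the series, on what has been measured and on what is new or still open speak of the compounds shown alone.

Measured compounds:
compound 1 `COCCNc1nc(NCC2CC2)cc(-c2ccccn2)n1` — 10000 nM
compound 2 `CN(C)c1nc(NCC2CC2)cc(-c2ccccn2)n1` — 6720 nM
compound 3 `CNc1nc(NC2(c3ccc(Cl)cc3)CCC2)cc(-c2ccccn2)n1` — 34 nM

All three were read in a functional assay on HEK293 cells for agonist activity at G-protein coupled receptor 39 (Mus musculus), read by inositol phosphate accumulation; on this read-out lower numbers stand for an effect already at smaller amounts and higher numbers for an effect only at larger amounts of compound. Compound 2 gives 6720 nM, the second highest of the three numbers; its nearest neighbour is compound 1 with 10000 nM, and the gap between them is within the scatter. Compound 3, with a different group on the other amino nitrogen, gives 34 nM and stands far apart from compound 2.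

Compound 4 `c1ccc(-c2cc(NCC3CC3)ncn2)nc1` is not yet measured. It differs from compound 2 in one place: hydrogen in place of dimethylamino on an aromatic carbon.

Among the compounds with values here, the only measured step, a 1.5-fold lower number from compound 1 to compound 2 (0.17 log units; within the scatter), exchanges one amino group for another at the same carbon and stays within the scatter; no measured step removes a group from that carbon altogether, so the size of the change in this assay cannot be read from the series. The expected step of a 1.5-fold higher number from compound 2 to compound 4 (0.17 log units; within the scatter) is therefore a guess weighted toward a higher number, since compound 2 is already weak. Compound 4 is estimated at 10000 nM, within 3000 nM to 35000 nM.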

Compound 4, half-maximal effective concentration: 10000 nM
The estimate for compound 4 equals the measured number at the digits printed; the range from low to high includes it.
By their numbers in this assay, from the lowest: compound 3; then compounds 2, 1 and 4 (each within the scatter of the next).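

In this assay, the carbon between two ring nitrogen atoms can lose its substituent altogether: hydrogen in place of dimethylamino gives a 1.5-fold higher number from compound 2 to compound 4 (0.17 log units; within the scatter), and hydrogen in place of (2-methoxyethyl)amino gives no change at the digits printed from compound 1 to compound 4 (within the scatter). Within the data shown here, earlier, only one amino group had been exchanged for another, whereas these steps show that, with the (cyclopropylmethyl)amino group held constant, neither amino group at this carbon gives a number separable from hydrogen. No evidence at hand bears on the reason for this result.

As far as these compounds go, it remains open whether this carbon is equally undemanding alongside the different amino group of compound 3, which gives 34 nM, where the methylamino group could be replaced by hydrogen. Also open, from the compounds shown here alone, is whether a carboxylic acid or a longer alkyl chain at this carbon moves the number beyond the scatter.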